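Swapping Methoxy for Trifluoromethyl Among Inactive Compounds

The compounds below may be only part of what the source reports. "The series", "measured", "known", "first", "only" and "open" are said of these compounds alone.

So far, three related compounds have been tested in a functional assay on CWR22R cells (Homo sapiens) for antiproliferative activity, with a stated time of 96 h (on this read-out lower numbers stand for stronger inhibition and higher numbers for weaker inhibition), and none of them gives an exact potency. Compound 1 `Cc1cc(=O)oc2cc(OCC(=O)c3ccc(OC(F)(F)F)cc3)ccc12` gives > 100000 nM, which is a limit of the assay and not a number. Compound 2 `O=C(COc1ccc2c(C(F)(F)F)cc(=O)oc2c1)c1ccccc1C(F)(F)F` is recorded as "not active" (no number reported). Compound 3 `COc1ccc(C(=O)COc2ccc3c(C(F)(F)F)cc(=O)oc3c2)cc1` is likewise recorded as "not active" (no number reported), so it stands at the inactive end of the results, without a single number to mark its place.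

One further structure, compound 4 `O=C(COc1ccc2c(C(F)(F)F)cc(=O)oc2c1)c1ccc(C(F)(F)F)cc1`, has not yet been measured. The structural change that leads to it is this: trifluoromethyl in place of methoxy on an aromatic carbon. In words, trifluoromethyl takes the place of methoxy on an aromatic carbon, para to a large group.

Among the compounds with values here, no pair of measured compounds differs in just one place, so no measured step can serve as a guide for this change. Compound 2, with "not active" (no number reported), carries trifluoromethyl on the same ring and still shows no reported activity. No step beyond the scatter is therefore expected in this assay, and compound 4 is expected to remain inactive, most likely without a reported number. If a number does appear, compound 4 is estimated at 100000 nM, with an expected range from 30000 nM to 200000 nM.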

Compound 4, half-maximal inhibitory concentration: "not active" (no number reported)
Compound 4: no number reported, so the estimate cannot be set against anything.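

Compound 3 and compound 4 are both recorded as not active in this assay, with no number for either, so no step can be read between them. The compounds shown leave open whether any change to this series gives a measurable potency, since the only entry near a value is a limit: the limit of > 100000 nM in this assay, at which 1 of the 4 values shown sits.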